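A few compounds are considered here, and "the series" means these few. Any claim that something is new, unique, unknown or untested is made for them only; others in the source may bear on it.

Measured compounds:
compound 1, `CC(/C=C/CC(C)CCCC(C)C)=C\C(=O)OC(C)(C)C`, gives 7.56 in a physicochemical assay for lipophilicity; a lower number here means a more polar compound, a higher number a more lipophilic compound;
compound 2, `COC(C)(C)CCCC(C)C/C=C/C(C)=C/C(=O)OC(C)(C)C`, gives 6.36;
compound 3, `CC(/C=C/CC(C)CCCC(C)(C)OC(C)C)=C\C(=O)OC(C)C`, gives 6.9.

Compound 1 holds the highest number of the three in this assay, with compound 3 the nearest and compound 2 the furthest from it. The one step that links two of these compounds by a single change is a number 1.20 log units lower from compound 1 to compound 2 (beyond the scatter), and it concerns a methoxy on a saturated chain carbon, a different part of the molecule from the change considered here.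

Compound 4, `CC(/C=C/CC(C)CCCC(C)C)=C\C(=O)CC(C)C`, is not yet measured. It differs from compound 1 in this way: isobutyl in place of tert-butoxy on a carbonyl carbon. Within the data shown here, no measured step bears directly on an exchange at the carbonyl carbon, so the expectation rests on the count of what leaves and what enters: one hydrogen-bond acceptor is lost, and an isobutyl of four carbons replaces a tert-butoxy of four carbons and an oxygen. The step is expected to be small, a number 0.26 log units lower from compound 1 to compound 4 (within the scatter), a little downward or none beyond the scatter. Compound 4 is therefore estimated at 7.3, within 6.8 to 7.8.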

Compound 4, partition coefficient: 7.22
The estimate for compound 4 lay 0.08 log units above the measured number, and the stated range covers the measured number.
By their numbers in this assay, from the lowest: compound 2; then compound 3; then compound 4; then compound 1.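

In this assay, the carbonyl carbon now has a measured step of its own: isobutyl in place of tert-butoxy gives a number 0.34 log units lower from compound 1 to compound 4 (beyond the scatter), so this exchange moves the number beyond the scatter, though only modestly. The number goes down even though the group that leaves holds the hydrogen-bond acceptor and 5 heavy atoms, while the group that enters holds no hydrogen-bond acceptor and 4 heavy atoms. Nothing among the data shown accounts for this direction.

This single pair does not separate the loss of the oxygen from the change from tert-butyl branching to isobutyl branching. It also leaves open how other groups on this carbonyl carbon, such as an amine or a longer chain, would compare, and whether the same exchange would give a similar step on compound 2.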